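This account rests on a few compounds, and the source may have more. Where it says the series, first, only, none or still open, it means among the compounds named here.

Compound 1 `CNC(=O)c1cc(Oc2ccc(C(=O)/C=C/c3cc(OC)c(OC)c(OC)c3)cc2)ccn1`: 3880 nM
Compound 2 `CNC(=O)c1cc(Oc2ccc(C(=O)/C=C/c3ccc(C#N)cc3)cc2)ccn1`: 9520 nM
Compound 3 `CNC(=O)c1cc(Oc2ccc(/C=C/C(=O)c3ccc(Cl)cc3)cc2)ccn1`: 17500 nM

Of the compounds shown here, three sharing the same core have been tested in a functional assay on MCF7 cells (Homo sapiens) for cytotoxicity, read by MTT assay, with a stated time of 72 h; on this read-out lower numbers stand for stronger inhibition and higher numbers for weaker inhibition. Compound 2 gives 9520 nM, the second highest of the three numbers. Its nearest neighbour is compound 3, whose value of 17500 nM lies within the scatter of compound 2, so no order between these two can be read. Compound 1, with 3880 nM, stands furthest from compound 2 and beyond the scatter, on the stronger side.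

Compound 4 `CNC(=O)c1cc(Oc2ccc(C(=O)/C=C/c3ccc(F)cc3)cc2)ccn1` has not yet been measured. It differs from compound 2 in one place: fluoro in place of cyano on an aromatic carbon. Within the data shown here, no pair of measured compounds shows what this change does in this assay, and nothing in the data bears on it directly. The step from compound 2 to compound 4 is expected to be small, a modest shift toward a higher number if anything, and most likely not beyond the scatter. The expected step is a 1.3-fold higher number from compound 2 to compound 4 (0.10 log units; within the scatter). Compound 4 is expected to give 12000 nM, within a range from 5000 nM to 30000 nM.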

Compound 4, half-maximal inhibitory concentration: 28500 nM
The estimate for compound 4 lay 2.4-fold (0.38 log units) below the measured number; low and high end bracket the measured number.
By their numbers in this assay, from the lowest: compound 1; then compounds 2, 3 and 4 (each within the scatter of the next, the first and the last beyond it).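

In this assay, the change from 4-cyanophenyl to 4-fluorophenyl, on the aromatic carbon para to a large group, gives a 3.0-fold higher number from compound 2 to compound 4 (0.48 log units; beyond the scatter) and moves toward weaker inhibition. Among these compounds, this is the first reading of a single change, since no two of the earlier compounds differed in one place only, and it shows that the group held at this position can alter the number beyond the scatter. No measurement at hand accounts for the size or the direction of this step.

A single pair cannot say whether the difference belongs more to the cyano group or to the fluoro group, and the same core carrying hydrogen, chloro, an amine or a carboxylic acid at this position would be needed to place the two on a wider scale. Going by these compounds, it also remains open whether fluoro in place of cyano would give a step of similar size and direction on the core of compound 1 or of compound 3, or in cells other than those of this single assay.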